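A few compounds are considered here, and "the series" means these few. Any claim that something is new, unique, unknown or untested is made for them only; others in the source may bear on it.

Working notes on the adenosine-like series bearing a substituted carbon on the shared core.

Compound 1 `CN(Cc1ncnc2c1ncn2[C@@H]1O[C@H](CO)[C@@H](O)[C@H]1O)c1ccccc1` carries methyl(phenyl)amino on a saturated chain carbon bound to an aromatic carbon; in a functional assay on Huh-7 cells (Homo sapiens) for cytotoxicity, read by MTT assay, with a stated time of 3 days (a higher number here means that more compound is tolerated, a lower number that less compound is tolerated), compound 1 gives 21000 nM. Compound 2 `OC[C@H]1O[C@@H](n2cnc3c(Cn4ccc5ccccc54)ncnc32)[C@H](O)[C@@H]1O` carries 1H-indol-1-yl at the same place, and compound 3 `CSCc1ncnc2c1ncn2[C@@H]1O[C@H](CO)[C@@H](O)[C@H]1O` carries methylsulfanyl there. In this assay compound 2 reaches only the limit > 250000 nM. For compound 3 the value is likewise a limit, > 100000 nM, so compound 3 stands at the limit of > 100000 nM in this assay, at which 1 of the 3 values shown sits, and no number is known for it. The steps of an at least 11-fold higher number from compound 1 to compound 2 (1.07 log units; beyond the scatter) and an at least 4.7-fold higher number from compound 1 to compound 3 (0.67 log units; beyond the scatter) both move away from compound 1 toward the limits; the step that the two limits leave unreadable from compound 2 to compound 3 cannot be read.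

Compound 4 `O=c1ccccn1Cc1ncnc2c1ncn2[C@@H]1O[C@H](CO)[C@@H](O)[C@H]1O` is the next member: a group of 7 heavy atoms (5 carbon, 1 nitrogen, 1 oxygen; one six-membered aromatic ring with 1 hetero atom) in place of a group of 2 heavy atoms (1 carbon, 1 sulfur; no ring), on a saturated chain carbon bound to an aromatic carbon. The steps from compound 1 show that an aromatic ring at this carbon can sit anywhere from the number of compound 1 to a limit, so the direction of the step into compound 4 cannot be fixed from these data. The step that the limit leaves unreadable from compound 3 to compound 4 is therefore expected to be unreadable against the limit of compound 3, with a fair chance that compound 4 also reports only a limit. The estimate for compound 4 in this assay is 120000 nM, ranging from 30000 nM to 400000 nM.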

Compound 4, half-maximal cytotoxic concentration: > 100000 nM
Compound 4 ended at the assay's limit (the forecaster's own chance of this, stated with the estimate: 60%); the middle value lies beyond the limit too.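

In this assay compound 4 gives only a limit, not a number, and it shares that limit with one earlier member of the series: the limit of > 100000 nM in this assay, at which 2 of the 4 values shown sit.

Among the compounds shown here, the only readable step is an at least 4.7-fold higher number from compound 1 to compound 4 (0.67 log units; beyond the scatter). For the compounds shown here, a six-membered aromatic ring with 1 hetero atom on this saturated chain carbon bound to an aromatic carbon therefore joins the 1H-indol-1-yl and methylsulfanyl groups at limits, and the methyl(phenyl)amino group remains the only one here with a number. The steps among the three limit-bound compounds cannot be read, so these data give no order among compound 2, compound 3 and compound 4.

As far as these compounds go, how far the true values of these three compounds lie beyond their limits remains open, and a single number at this carbon is too little to show which feature of the methyl(phenyl)amino group goes with lower tolerance. Also open, from the compounds shown here alone, is how a simple dimethylamino group, a carboxylic acid or a longer alkyl chain at this carbon would read in this assay.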